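The source may hold more compounds than are shown below. What is called first, only, known or untested is meant among the compounds shown, and "the series" means these compounds.

Compound 3 `O=C1C(Nc2ccc(I)cc2)=CC(=O)c2ncncc21` gives 0.01 ug/mL in a functional assay on HCT-15 cells (Homo sapiens) for cytotoxicity, read by MTT assay, with a stated time of 72 h (on this read-out higher numbers stand for weaker inhibition and lower numbers for stronger inhibition), the lowest of the three numbers shown, though within the scatter of both of the others: compound 1 `CCOc1ccc(NC2=CC(=O)c3ncncc3C2=O)cc1` gives 0.02 ug/mL and compound 2 `O=C1C(Nc2ccc(F)cc2)=CC(=O)c2ncncc21` gives 0.02 ug/mL. Compound 4 `O=C1C(Nc2ccc(Br)cc2)=CC(=O)c2ncncc21` differs from compound 3 by bromo in place of iodo on an aromatic carbon. The step that bears on it most closely is the exchange of one halogen for another, a 2.0-fold lower number from compound 2 to compound 3 (0.30 log units; within the scatter); the exchange a 2.0-fold lower number from compound 1 to compound 3 (0.30 log units; within the scatter) was of the same size. Both stayed within the scatter, so the expected step here, a 1.5-fold higher number from compound 3 to compound 4 (0.18 log units; within the scatter), is none beyond the scatter. Compound 4 is therefore expected to give 0.015 ug/mL, in the range 0.006 ug/mL to 0.04 ug/mL.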

Compound 4, half-maximal inhibitory concentration: 0.01 ug/mL
Beside the measured number, compound 4's estimate is 1.5-fold (0.18 log units) above it; the range from low to high includes it.
By their numbers in this assay, from the lowest: compounds 3, 4, 1 and 2 (each within the scatter of the next).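

In this assay, bromo in place of iodo gives no change at the digits printed from compound 3 to compound 4 (within the scatter) and bromo in place of fluoro gives a 2.0-fold lower number from compound 2 to compound 4 (0.30 log units; within the scatter) while bromo in place of ethoxy gives a 2.0-fold lower number from compound 1 to compound 4 (0.30 log units; within the scatter) at this place on the aromatic ring. Within the data shown here, with bromo added, ethoxy and all three halogens remain within the scatter of one another, so no step at this place separates any pair of the four compounds. No available evidence explains this sameness.

Open, as far as these compounds go, is whether an amine, a carboxylic acid or a longer chain at this place would give a step beyond the scatter. Also open, from the compounds shown here alone, is whether a change to the shared core would do so.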